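Swapping Ethyl for Methoxy on the Shared Core

This account rests on a few compounds, and the source may have more. Where it says the series, first, only, none or still open, it means among the compounds named here.

Of the compounds shown here, three sharing one core have been tested in a functional assay on A-375 cells (Homo sapiens) for antiproliferative activity, read by MTT assay, with a stated time of 24 h, tested at 3.7 ug/mL; a lower number here means a weaker effect, a higher number a stronger effect of the compound at the concentration tested. Compound 1 `CCc1ccc2nc(C(=O)Nc3c(F)cc(-c4cccc(F)c4)cc3F)c(C)c(O)c2c1` gives 17.9%, compound 2 `Cc1c(C(=O)Nc2c(F)cc(-c3cccc(F)c3)cc2F)nc2ccc(C(F)(F)F)cc2c1O` gives 34.3%, and compound 3 `CCc1ccc2nc(C(=O)Nc3c(F)cc(-c4cccc(F)c4)cc3F)c(C)c(C(=O)O)c2c1` gives 26.7%. Compound 3 therefore sits close to both compound 2 and compound 1, with all three lying within the usual scatter of one another. Compound 4 `COc1ccc2nc(C(=O)Nc3c(F)cc(-c4cccc(F)c4)cc3F)c(C)c(C(=O)O)c2c1` differs from compound 3 by methoxy in place of ethyl on an aromatic carbon. Among the measured compounds shown here, only one measured step touches this same place on the core: a number 16.4 percentage points higher from compound 1 to compound 2 (beyond the scatter). The other step, a number 8.8 percentage points higher from compound 1 to compound 3 (within the scatter), concerns a different group. For the measured compounds named here, no measured step swaps ethyl for methoxy, so only a small change, if any, is expected: a number 1.3 percentage points higher from compound 3 to compound 4 (within the scatter). Compound 4 is therefore estimated at 28%, with a range from 13% to 43%.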

Compound 4, a percentage reported as inhibition, at one concentration (the size of the read-out at that concentration, not a potency): 24.6%
For compound 4 the middle estimate is 3.4 percentage points above the measured one, within the range that was stated.
By their numbers in this assay, from the lowest: compounds 1, 4, 3 and 2 (each within the scatter of the next, the first and the last beyond it).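

With the carboxy group in place on the shared core, methoxy in place of ethyl on this aromatic carbon gives in this assay a number 2.1 percentage points lower from compound 3 to compound 4 (within the scatter), so this swap has no effect that can be told apart from the scatter. Among the compounds shown here, the only other step at this position, a number 16.4 percentage points higher from compound 1 to compound 2 (beyond the scatter), brings in trifluoromethyl and has hydroxy rather than carboxy on the core. Nothing available explains either result.

On these data alone, whether an amine or a longer chain such as propyl would move the number beyond the scatter remains open. So does how methoxy behaves with hydroxy on the core.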